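The source may hold more compounds than are shown below. What is called first, only, known or untested is meant among the compounds shown, and "the series" means these compounds.

Compound 1 `ClCc1cccc(Cn2cnc3ncnc(Cl)c32)c1` and compound 2 `ClCc1cccc(Cn2cnc3c(Cl)ncnc32)c1` are built from the same atoms joined differently; the difference between the two cores is not broken down here. In a functional assay on SK-MEL-2 cells (Homo sapiens) for cytotoxicity, read by sulforhodamine B assay, with a stated time of 48 h (a lower number here means a stronger inhibitor of growth, a higher number a weaker inhibitor of growth), compound 1 gives 22900 nM and compound 2 gives 51300 nM. Compound 3 `ClCc1cccc(Cn2cnc3c(Cl)nc(Cl)nc32)c1` differs from compound 2 by one change, (chloro in place of hydrogen on an aromatic carbon), and in this assay compound 3 gives 4460 nM. That single change brought a 12-fold lower number from compound 2 to compound 3 (1.06 log units; beyond the scatter). Compound 4 `ClCc1cccc(Cn2cnc3nc(Cl)nc(Cl)c32)c1` has not yet been measured. It differs from compound 1 by the same change, (chloro in place of hydrogen on an aromatic carbon), at a place described in the same words, but set on the other core. Within the data shown here, whether the layout of the core alters the effect of this change cannot be read from the compounds measured so far. Among the measured compounds shown here, for compound 4 the expected 6.5-fold lower number from compound 1 to compound 4 (0.82 log units; beyond the scatter) rests on a 12-fold lower number from compound 2 to compound 3 (1.06 log units; beyond the scatter) and is kept somewhat smaller than that step; it is the only example of the change available, and it was seen on a different core. Compound 4 is therefore estimated to give 3500 nM in this assay, with a plausible span from 1200 nM to 11000 nM.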

Compound 4, concentration for total growth inhibition: 3710 nM
Estimate against measurement, compound 4: 1.1-fold (0.03 log units) below, within the range that was stated.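

In this assay, putting chloro in place of hydrogen on an aromatic carbon of the core of compound 1 gave a 6.2-fold lower number from compound 1 to compound 4 (0.79 log units; beyond the scatter), so the number fell on this core too. Set beside the earlier example, the two steps point the same way and cannot be told apart in size: the same change on two cores in this assay, a 12-fold lower number (1.06 log units; beyond the scatter) from compound 2 to compound 3 and a 6.2-fold lower number (0.79 log units; beyond the scatter) from compound 1 to compound 4, 1.9-fold (0.27 log units) apart, within the scatter of two such steps. Among these compounds, in this series the change therefore carried over from one core to the other, but this rests on only two pairs of compounds in a single cell line, and it neither predicts the step on any further core nor explains why the number falls.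

Among the compounds shown, only hydrogen and chloro occupy this place, so it remains open whether an amine, a methoxy group or a longer chain there would also lower the number. Going by these compounds, it is also open whether the step seen with chloro would hold in other cell types.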